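Chloro in Place of Methyl on an Aromatic Carbon

The compounds below may be only part of what the source reports. "The series", "measured", "known", "first", "only" and "open" are said of these compounds alone.

Compound 1 `Cc1ccc(NC(=O)c2coc3ccc(C)cc3c2=O)cc1` gives 152 nM in an assay on cells for inhibition of Amine oxidase [flavin-containing] B (Homo sapiens), read by fluorescence and Amplex Red, using microsomes, with a stated time of 15 min; a lower number here means a stronger inhibitor, a higher number a weaker inhibitor. Compound 2 `Cc1ccc2occ(C(=O)Nc3ccc(Cl)cc3)c(=O)c2c1` gives 45.4 nM in this assay. The change between them is chloro in place of methyl on an aromatic carbon, and it produced a 3.3-fold lower number from compound 1 to compound 2 (0.52 log units; beyond the scatter). Compound 3 `COc1ccc2occ(C(=O)Nc3cccc(C)c3)c(=O)c2c1` gives 21.8 nM in this assay; how its core differs from that of compound 1 is not broken down here. Compound 4 `COc1ccc2occ(C(=O)Nc3cccc(Cl)c3)c(=O)c2c1` is not yet measured and differs from compound 3 by chloro in place of methyl on an aromatic carbon. This is the same kind of change as that from compound 1 to compound 2, but not the same: there the chloro stands para to a large group, here meta to a large group. Compound 4 is expected to show a 2.2-fold lower number from compound 3 to compound 4 (0.34 log units; beyond the scatter) in this assay, a somewhat smaller step, because a 3.3-fold lower number from compound 1 to compound 2 (0.52 log units; beyond the scatter) arose with the chloro para to a large group and here it stands meta to a large group. Compound 4 is therefore estimated at 10 nM, between 4 nM and 25 nM.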

Compound 4, half-maximal inhibitory concentration: 3.94 nM
Beside the measured number, compound 4's estimate is 2.5-fold (0.40 log units) above it; measured number outside the range, below it.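

In this assay the change from methyl to chloro gave a 5.5-fold lower number from compound 3 to compound 4 (0.74 log units; beyond the scatter). Set beside the earlier case, the step carried over from one core to the other in direction and, within the scatter, in size: the same change on two cores in this assay, a 3.3-fold lower number (0.52 log units; beyond the scatter) from compound 1 to compound 2 and a 5.5-fold lower number (0.74 log units; beyond the scatter) from compound 3 to compound 4, 1.7-fold (0.22 log units) apart, within the scatter of two such steps. Among these compounds, these are only two pairs, however, and core and chloro position both differ between them, so they neither separate the two influences nor show that the step would hold on any further core.

The compounds shown leave open whether a bromo or an amine in place of the chloro on the phenyl ring would lower the number further or raise it. They also leave open what a longer chain in place of the methoxy on the core would do.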